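The compounds below may be only part of what the source reports. "The series", "measured", "known", "first", "only" and "open" are said of these compounds alone.

Of the compounds shown here, three sharing one core have been measured in a functional assay on CHO cells for antagonist activity at 5-hydroxytryptamine receptor 6 (Homo sapiens), read by FLIPR (on this read-out higher numbers stand for weaker inhibition and lower numbers for stronger inhibition), and all of them differ only in the group attached to the sulfonyl sulfur. Compound 1 `CN1CCC(N(C)C(=O)C2CN(S(=O)(=O)c3ccc4ccccc4c3)c3ccccc32)CC1` carries a bicyclic all-carbon aromatic group there and gives 25.1 nM. Compound 2 `CN1CCC(N(C)C(=O)C2CN(S(=O)(=O)C3=CC4CCOC4C=C3)c3ccccc32)CC1`, with a partly saturated bicyclic group holding one oxygen, gives 31.6 nM; the step of a 1.3-fold higher number from compound 1 to compound 2 (0.10 log units; within the scatter) does not separate the two. Compound 3 `CN1CCC(N(C)C(=O)C2CN(S(=O)(=O)c3cccc4nsnc34)c3ccccc32)CC1`, which carries the bicyclic heteroaromatic group, gives 126 nM and therefore stands at the weakest end of this small set, with a 5.0-fold higher number from compound 1 to compound 3 (0.70 log units; beyond the scatter) and a 4.0-fold higher number from compound 2 to compound 3 (0.60 log units; beyond the scatter) both lying beyond the scatter.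

Compound 4 `CN1CCC(N(C)C(=O)C2CN(S(=O)(=O)c3ccc(C(F)(F)F)cc3)c3ccccc32)CC1` is the next step from compound 3: a group of 10 heavy atoms (7 carbon, 3 fluorine; one six-membered aromatic ring of carbon only) in place of a group of 9 heavy atoms (6 carbon, 2 nitrogen, 1 sulfur; one five-membered aromatic ring with 3 hetero atoms, one six-membered aromatic ring of carbon only), on a sulfonyl sulfur. Within the data shown here, no measured pair exchanges a bicyclic sulfonyl substituent for a single ring, so the two steps into compound 3 are the only guide. Both show that the heteroaromatic bicycle is the unfavourable member, and a return to a plain carbon aromatic ring is expected to move the number back toward that of compound 1, though the single ring leaves room for either outcome. The step is thus expected to be a 3.2-fold lower number from compound 3 to compound 4 (0.50 log units; beyond the scatter), and compound 4 is estimated at 40 nM, within a range from 12 nM to 130 nM.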

Compound 4, inhibition constant: 25.1 nM
For compound 4 the middle estimate is 1.6-fold (0.20 log units) above the measured one; measured number inside the range.
By their numbers in this assay, from the lowest: compounds 1, 4 and 2 (each within the scatter of the next); then compound 3.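

In this assay, the exchange at the sulfonyl sulfur gives a 5.0-fold lower number from compound 3 to compound 4 (0.70 log units; beyond the scatter), so a single aromatic ring of carbon only can stand in this place without the loss seen with the bicyclic heteroaromatic group, and compound 3 is now the weakest of the four by steps beyond the scatter. The single ring also cannot be told apart from either bicyclic group, with a 1.3-fold lower number from compound 2 to compound 4 (0.10 log units; within the scatter) and no change at the digits printed from compound 1 to compound 4 (within the scatter), which shows that, among these compounds, a second ring on the sulfonyl sulfur is not required for the numbers reached by compound 1 and compound 2. Nothing available here accounts for why the bicyclic heteroaromatic group alone stands apart.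

The compounds shown leave open whether the trifluoromethyl group contributes at all, as a plain phenyl group on the sulfonyl sulfur is not among them to set against compound 4. They also leave open whether the loss in compound 3 follows from its ring nitrogens and sulfur in general or only from that particular bicycle, which a pyridine or thiophene ring in the same place would help to separate.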